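The source may hold more compounds than are shown below. What is called first, only, known or untested is meant among the compounds shown, and "the series" means these compounds.

Compound 1 `OCC1C=CC(n2cnc3c(O)ncnc32)O1`: 60000 nM
Compound 2 `Nc1ncnc2c1ncn2[C@H]1C=C[C@@H](CO)O1`: 59000 nM

Among the measured compounds shown here, in a functional assay (Homo sapiens) (a lower number here means a stronger inhibitor, a higher number a weaker inhibitor), compound 1 gives 60000 nM, within the scatter of compound 2 at 59000 nM, so the two stand level and no measured step offers guidance. Compound 3 `Nc1nc(O)c2ncn(C3C=CC(CO)O3)c2n1` differs from compound 1 by amino in place of hydrogen on an aromatic carbon, between two ring nitrogen atoms. A modest gain in inhibition is expected, with the estimated step being a 2.0-fold lower number from compound 1 to compound 3 (0.30 log units; within the scatter), though it may not clear the scatter. Compound 3 is estimated at 30000 nM, with an expected range of 6000 nM to 120000 nM.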

Compound 3, half-maximal inhibitory concentration: > 100000 nM
Compound 3: a limit, no number (the forecaster's own chance of this, stated with the estimate: 25%); middle value at least 3.3-fold (0.52 log units) from the limit.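

In this assay compound 3 gives a limit and not a number: the limit of > 100000 nM in this assay, at which 1 of the 3 values shown sits. Amino in place of hydrogen on an aromatic carbon, between two ring nitrogen atoms, therefore brings no sign of stronger inhibition at this position, the step being an at least 1.6-fold higher number from compound 1 to compound 3 (0.22 log units; that floor lies within the scatter). Since that floor lies within the scatter, the weakening itself is not established.

Going by these compounds, how far compound 3 lies past its limit stays open. So does whether a methyl group or a chlorine atom at this same position would behave differently from amino.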